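This account rests on a few compounds, and the source may have more. Where it says the series, first, only, none or still open, it means among the compounds named here.

In an ADME assay on HepG2 cells (Homo sapiens) for cytotoxicity, read by MTT assay, with a stated time of 24 h (a higher number here means that more compound is tolerated, a lower number that less compound is tolerated), compound 1 `CC(C)=CCC1=C(OCc2cn(-c3cccnc3)nn2)C(=O)c2ccccc2C1=O` gives 1030000 nM, and compound 2 `CC(C)=CCC1=C(OCc2cn(-c3ccc(Cl)cc3)nn2)C(=O)c2ccccc2C1=O` gives 1150000 nM; on these two numbers compound 2 has the highest, with compound 1 within the scatter of it. Compound 3 `COc1cc([N+](=O)[O-])ccc1-n1cc(COC2=C(CC=C(C)C)C(=O)c3ccccc3C2=O)nn1` differs from compound 2 by 2-methoxy-4-nitrophenyl in place of 4-chlorophenyl on an aromatic nitrogen. Among the measured compounds shown here, the only step that bears on it is the aryl swap from compound 1 to compound 2, a 1.1-fold higher number from compound 1 to compound 2 (0.05 log units; within the scatter), which lay within the scatter, so no step beyond the scatter is expected in this assay here either. Compound 3 is therefore estimated at 1000000 nM in this assay, between 400000 nM and 2500000 nM, a step of a 1.2-fold lower number from compound 2 to compound 3 (0.06 log units; within the scatter).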

Compound 3, half-maximal cytotoxic concentration: 701000 nM
Estimate against measurement, compound 3: 1.4-fold (0.15 log units) above, within the range that was stated.
By their numbers in this assay, from the lowest: compounds 3, 1 and 2 (each within the scatter of the next).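

In this assay the swap to 2-methoxy-4-nitrophenyl gives a 1.6-fold lower number from compound 2 to compound 3 (0.21 log units; within the scatter) and, set against pyridin-3-yl, a 1.5-fold lower number from compound 1 to compound 3 (0.17 log units; within the scatter) on the same aromatic nitrogen. Among the compounds shown here, three different aryl groups have now stood at this position, one of them carrying two substituents, and no step among compound 1, compound 2 and compound 3 leaves the scatter. Nothing measured here accounts for this result.

The compounds shown leave open whether an aryl bearing an amine or a carboxylic acid, or a plain alkyl chain in place of the aryl, would move the number beyond the scatter. From the compounds shown here alone, all three share one core, so how these steps carry over to another core also stays open.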